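The compounds below may be only part of what the source reports. "The series", "measured", "known", "first", "only" and "open" are said of these compounds alone.

Measured so far:
- Compound 1 `O=C1NCCN1CCN1CCC(n2cc(-c3ccc(F)cc3)c3cc(F)ccc32)CC1`: 19 nM
- Compound 2 `Cc1ccc2c(c1)c(-c1ccc(F)cc1)cn2C1CCN(CCN2CCN(C(C)C)C2=O)CC1`: 280 nM

In an assay on cell membranes for displacement of a labelled ligand from Alpha-1A adrenergic receptor (Rattus norvegicus) (on this read-out higher numbers stand for weaker inhibition and lower numbers for stronger inhibition), compound 1 gives 19 nM and compound 2 gives 280 nM. Of these two numbers, compound 2 has the higher one; the gap to compound 1 lies well beyond the usual scatter, and the two compounds differ in more than one place, so no single change can be credited for it.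

Compound 3 `Cc1ccc2c(c1)c(-c1ccc(F)cc1)cn2C1CCN(C)CC1` is not yet measured. It differs from compound 2 in one place only: hydrogen in place of (3-isopropyl-2-oxoimidazolidin-1-yl)methyl on a saturated chain carbon bound to an amine nitrogen in a ring. Most of the side chain on the ring nitrogen is thus removed, leaving a small group.

Among the compounds with values here, no measured pair shows what such a removal does here. The expectation is that compound 3 binds more weakly than compound 2, with a step of about a 5.4-fold higher number from compound 2 to compound 3 (0.73 log units; beyond the scatter) in this assay. Compound 3 is estimated at 1500 nM, within a range of 300 nM to 8000 nM.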

Compound 3, half-maximal inhibitory concentration: 190 nM
Beside the measured number, compound 3's estimate is 7.9-fold (0.90 log units) above it; measured number below the stated range.
By their numbers in this assay, from the lowest: compound 1; then compounds 3 and 2 (each within the scatter of the next).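

Compound 3 carries methyl where compound 2 carries 2-(3-isopropyl-2-oxoimidazolidin-1-yl)ethyl on the amine nitrogen in a ring. In this assay there is a 1.5-fold lower number from compound 2 to compound 3 (0.17 log units; within the scatter). On this core, then, nearly the whole side chain can go without a change that this read-out can separate from scatter, which the gap between compound 1 and compound 2 could not show, since those two differ in more than one place. Nothing available gives a reason for this result.

Left open is whether methyl in place of the side chain would be tolerated in the same way on the core of compound 1, which gives 19 nM. Also open, from the compounds shown here alone, is what a plain hydrogen, a benzyl group or a longer chain ending in an amine or a carboxylic acid would do on that nitrogen.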